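A few compounds are considered here, and "the series" means these few. Any claim that something is new, unique, unknown or untested is made for them only; others in the source may bear on it.

Measured compounds in this series:

- compound 1, `COc1nc(C(C)(C)C)ccc1[C@@H](c1ccccc1)[C@@](O)(CCN(C)C)c1cccc2ccccc12`
- compound 2, `COc1nc(-c2ccc(Cl)c(F)c2)ccc1[C@@H](c1ccccc1)[C@@](O)(CCN(C)C)c1cccc2ccccc12`

In a toxicity assay on HeLa cells (Homo sapiens) for cytotoxicity (a higher number here means that more compound is tolerated, a lower number that less compound is tolerated), compound 1 gives > 64 ug/mL, which is a limit of the assay and not a number. In this assay compound 2 likewise gives > 64 ug/mL, again a limit. Both values sit at the same ceiling, (the limit of > 64 ug/mL in this assay, at which 2 of the 2 values shown sit), so compound 2 stands only at a limit, with no number of its own. For the measured compounds named here, the single measured step, a step that the two limits leave unreadable from compound 1 to compound 2, cannot be read: both of its ends are limits, so neither its size nor its direction is known.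

Compound 3, `COc1nc(-c2cccc(F)c2)ccc1[C@@H](c1ccccc1)[C@@](O)(CCN(C)C)c1cccc2ccccc12`, is the next compound. Relative to compound 2 the change is hydrogen in place of chloro on an aromatic carbon. Going by the values given here, no measured step bears directly on this change; the only step in hand is the unreadable one from the tert-butyl to the 4-chloro-3-fluorophenyl compound. With both measured compounds at the limit, the expectation for compound 3 is that it stays at or near that limit, and the estimated step that the limit leaves unreadable from compound 2 to compound 3 is expected to be none beyond the scatter. Compound 3 is thus expected at 80 ug/mL, within a range of 40 ug/mL to 200 ug/mL.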

Compound 3, half-maximal cytotoxic concentration: 62.8 ug/mL
Beside the measured number, compound 3's estimate is 1.3-fold (0.11 log units) above it; low and high end bracket the measured number.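

In this assay the 3-fluorophenyl group of compound 3 gives the series its first reading that is a number and not a limit, so this position on the shared core now has a value against which further changes can be set. Hydrogen in place of chloro gives an at least 1.0-fold lower number from compound 2 to compound 3 (0.00 log units; that floor lies within the scatter), and 3-fluorophenyl in place of tert-butyl gives an at least 1.0-fold lower number from compound 1 to compound 3 (0.00 log units; that floor lies within the scatter), so neither change is shown to move the number in this assay beyond the scatter, while the true size of each remains unknown. Both steps are floors alone, and the remaining step cannot be read, with both of its ends at a limit: the limit of > 64 ug/mL in this assay, at which 2 of the 3 values shown sit.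

Whether the fluoro group has any bearing on the reading stays open, as the compounds shown do not include a plain phenyl at this position. For the compounds shown here, also open is whether a different kind of group here, such as an amine or a carboxylic acid, would give a number clearly apart from the one for compound 3.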